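Carbamoyl for 4-nitrophenyl: notes on the series

The compounds below may be only part of what the source reports. "The series", "measured", "known", "first", "only" and "open" are said of these compounds alone.

- compound 1 `Cc1nn(-c2ccccc2)c(Oc2ccc(-c3nc4cc([N+](=O)[O-])ccc4[nH]3)cc2)c1/C=N/NC(N)=O`: 47700 nM
- compound 2 `Cc1nn(-c2ccccc2)c(Oc2ccc(-c3nc4cc(C(N)=O)ccc4[nH]3)cc2)c1/C=N/Nc1ccc([N+](=O)[O-])cc1`: 45500 nM

In a functional assay on HepG2 cells (Homo sapiens) for cytotoxicity, read by sulforhodamine B assay, with a stated time of 48 h (on this read-out higher numbers stand for weaker inhibition of growth and lower numbers for stronger inhibition of growth), compound 2 and compound 1 lie within the scatter of each other. Compound 3 `Cc1nn(-c2ccccc2)c(Oc2ccc(-c3nc4cc(C(N)=O)ccc4[nH]3)cc2)c1/C=N/NC(N)=O` differs from compound 2 by carbamoyl in place of 4-nitrophenyl on an amine nitrogen. Going by the values given here, no measured pair isolates this change. Compound 1 also carries carbamoyl at this place and gives 47700 nM, so no shift beyond the scatter is expected in this assay. The estimated step is a 1.0-fold lower number from compound 2 to compound 3 (0.00 log units; within the scatter). Compound 3 is estimated at 45000 nM, with an expected range of 20000 nM to 100000 nM.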

Compound 3, concentration for 50% growth inhibition: 9600 nM
Beside the measured number, compound 3's estimate is 4.7-fold (0.67 log units) above it; measured number outside the range, below it.
By their numbers in this assay, from the lowest: compound 3; then compounds 2 and 1 (each within the scatter of the next).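

In this assay, carbamoyl in place of 4-nitrophenyl on an amine nitrogen gives a 4.7-fold lower number from compound 2 to compound 3 (0.68 log units; beyond the scatter), and carbamoyl in place of nitro on an aromatic carbon gives a 5.0-fold lower number from compound 1 to compound 3 (0.70 log units; beyond the scatter). Each step is read with carbamoyl already present at the other place, and compound 3 is the only compound shown with carbamoyl at both. No measurement shown bears on the reason for either step.

On these data alone, whether either step holds with nitro and 4-nitrophenyl together remains open. So does the effect of a carboxylic acid on the aromatic carbon or an acetyl on the amine nitrogen.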